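A few compounds are considered here, and "the series" means these few. Any claim that something is new, unique, unknown or untested is made for them only; others in the source may bear on it.

The study follows a series built on one shared core, shown in compound 1 `C[C@]1(C(=O)N2CC[C@](c3ccc(C(F)(C(F)(F)F)C(F)(F)F)cc3)(S(=O)(=O)c3ccc(F)cc3)C2)CC[C@@H](C(=O)O)CC1` and carried unchanged into compound 2 `O=C1NC(=O)C2(CCC(C(=O)N3CC[C@](c4ccc(C(F)(C(F)(F)F)C(F)(F)F)cc4)(S(=O)(=O)c4ccc(F)cc4)C3)CC2)N1` and compound 3 `CC1(C(=O)N2CC[C@](c3ccc(C(F)(C(F)(F)F)C(F)(F)F)cc3)(S(=O)(=O)c3ccc(F)cc3)C2)CCS(=O)(=O)CC1`. In an ADME assay on microsomes from liver (Homo sapiens) for metabolic stability, with a stated time of 10 min (a lower number here means that less of the compound is left, a higher number that more of the compound is left), compound 1 gives 85%, and compound 2 gives 84%; 93% (2 entries), values that lie within the usual scatter of one another; for compound 3 the record shows "not determined" (no result reported). Compound 1 stands therefore at the only single number shown, beside the several entries of compound 2 (the several entries of compound 2 in this assay, 84%; 93% (2 entries)).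

The piece now turns to compound 4 `O=C(N1CC[C@](c2ccc(C(F)(C(F)(F)F)C(F)(F)F)cc2)(S(=O)(=O)c2ccc(F)cc2)C1)C1(O)CCS(=O)(=O)CC1`, which differs from compound 1 in one place (4-hydroxy-1,1-dioxothian-4-yl in place of 4-carboxy-1-methylcyclohexyl on a carbonyl carbon). Among the compounds with values here, no measured step between two compounds of this kind is available, so the expectation rests on compound 1 and compound 2 alone: compound 4 is expected to stay within the scatter, which reads as no change at the digits printed from compound 1 to compound 4 (within the scatter). Compound 4 is thus estimated at 85%, between 70% and 97%.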

Compound 4, percent of the compound remaining: 100%
Compound 4: the middle estimate sits 15 percentage points below what was measured; measured number above the stated range.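

Within the data shown here, the change on the carbonyl carbon is the first step at this position that can be read in this assay, and the swap to 4-hydroxy-1,1-dioxothian-4-yl gives a number 15 percentage points higher from compound 1 to compound 4 (beyond the scatter). This shows that the position is not silent, although the step is modest and repeat readings of one compound can also spread: the several entries of compound 2 in this assay, 84%; 93% (2 entries)

Among these compounds, the single step does not separate the loss of the carboxylic acid from the arrival of the hydroxy group or the dioxo-bearing sulfur. From the compounds shown here alone, how an amine or an open-chain group at this place would read remains open.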